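Pyrimidin-2-yl on the amide nitrogen of compound 4

A few compounds are considered here, and "the series" means these few. Any claim that something is new, unique, unknown or untested is made for them only; others in the source may bear on it.

Among the compounds with values here, compound 3 `COCCN(Cc1cccs1)C(=O)COc1ccc(C)cc1` stands second highest of the three numbers so far in an assay on HEK293 cells for agonist activity at transient receptor potential cation channel subfamily M member 8 (Homo sapiens), read by fluorescence and calcium flux, with a stated time of 15 min (a higher number here means that more compound is needed for the effect, a lower number that less compound is needed), where compound 3 gives 400 nM. Compound 1 `Cc1ccc(OCC(=O)N(Cc2cccs2)C2COC2)cc1` gives 23000 nM, and compound 2 `Cc1ccc(OCC(=O)N(Cc2cccs2)c2c(C)n[nH]c2C)cc1` gives 0.3 nM. Compound 3 is nearer compound 1 than compound 2: a 58-fold lower number from compound 1 to compound 3 (1.76 log units; beyond the scatter), whereas a 1300-fold higher number from compound 2 to compound 3 (3.12 log units; beyond the scatter).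

Compound 4 `Cc1ccc(OCC(=O)N(Cc2cccs2)c2ncccn2)cc1` differs from compound 3 in one place: pyrimidin-2-yl in place of 2-methoxyethyl on an amide-type nitrogen. Within the data shown here, two measured steps bear on this exchange. The step from compound 2 to compound 3 covers the same position and is large, as is a 77000-fold lower number from compound 1 to compound 2 (4.88 log units; beyond the scatter), where an aromatic ring with hetero atoms entered on the amide-type nitrogen. The ring entering in compound 4 is a six-membered aromatic ring with two nitrogens and no hydrogen-bond donor, not the 3,5-dimethyl-1H-pyrazol-4-yl of compound 2, so a large step toward a lower number is expected, but not the whole of the gap seen between compound 3 and compound 2. Compound 4 is therefore estimated at 30 nM, with a range from 3 nM to 400 nM. This means an expected step of a 13-fold lower number from compound 3 to compound 4 (1.12 log units; beyond the scatter).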

Compound 4, half-maximal effective concentration: 3700 nM
Beside the measured number, compound 4's estimate is 120-fold (2.09 log units) below it; measured number outside the range, above it.
By their numbers in this assay, from the lowest: compound 2; then compound 3; then compound 4; then compound 1.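

At this place on the amide-type nitrogen, an aromatic ring with hetero atoms does not by itself lower the number in this assay: pyrimidin-2-yl in place of 2-methoxyethyl gives a 9.3-fold higher number from compound 3 to compound 4 (0.97 log units; beyond the scatter), opposite in direction to the change seen with 3,5-dimethyl-1H-pyrazol-4-yl. The identity of the ring matters greatly, with a 12000-fold higher number from compound 2 to compound 4 (4.09 log units; beyond the scatter). Oxetan-3-yl remains the highest of the four, with a 6.2-fold lower number from compound 1 to compound 4 (0.79 log units; beyond the scatter).

Nothing measured here accounts for these differences. Open, on these data alone, is whether the ring hydrogen on nitrogen or the two methyl groups of 3,5-dimethyl-1H-pyrazol-4-yl carry the low number; 1H-pyrazol-4-yl, 1-methyl-1H-pyrazol-4-yl or phenyl on the amide-type nitrogen would separate these.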